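The source may hold more compounds than are shown below. What is called first, only, known or untested is meant among the compounds shown, and "the series" means these compounds.

Compound 1 `Clc1nss/c1=N\c1ccc(OCc2ccccc2)cc1` gives > 100000 nM in a functional assay on PANC-1 cells (Homo sapiens) for cytotoxicity, read by resazurin assay, with a stated time of 72 h; a higher number here means a weaker inhibitor, a lower number a stronger inhibitor; this is a limit of the assay, not a number.
Compound 2 `Clc1nss/c1=N\c1ccc(Oc2ccccc2)cc1` gives 55000 nM in this assay.
Compound 3 `FC(F)(F)Oc1ccc(/N=c2\ssnc2Cl)cc1Br` gives > 100000 nM in this assay; this too is a limit, not a number.

Compound 3 therefore stands at the edge of what this assay can report, sharing that position with compound 1 (the limit of > 100000 nM in this assay, at which 2 of the 3 values shown sit). Only compound 2 returned a number, and it is a weak one.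

Compound 4 `Clc1nss/c1=N\c1cccc(Br)c1` differs from compound 3 in one place: hydrogen in place of trifluoromethoxy on an aromatic carbon. Among the compounds with values here, the only measured step, an at least 1.8-fold lower number from compound 1 to compound 2 (0.25 log units; that floor lies within the scatter), concerns the group on an oxygen and not the trifluoromethoxy group, so it does not bear on this change, and its floor lies within the scatter in any case. Within the data shown here, no measured step thus tells how removing trifluoromethoxy shifts the number, and from compound 3 only a limit is known.

The step from compound 3 to compound 4 is expected to be an at least 1.2-fold lower number from compound 3 to compound 4 (0.09 log units; that floor lies within the scatter), which is an estimate rather than a measurement. Compound 4 is therefore expected at about 80000 nM, with a range from 25000 nM to 250000 nM, and a real chance that only a limit is reported.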

Compound 4, half-maximal inhibitory concentration: 38000 nM
The estimate for compound 4 lay 2.1-fold (0.32 log units) above the measured number; the measured number falls inside the stated range.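

Taking the trifluoromethoxy group off the aromatic carbon ortho to a bromo group gives an at least 2.6-fold lower number from compound 3 to compound 4 (0.42 log units; beyond the scatter), the first change among these compounds whose size clears the scatter. The trifluoromethoxy group is therefore not needed for a measurable number in this assay, although compound 4 is still weak at 38000 nM. The size of the step is only a floor, because the value of compound 3 is a limit and not a number: the limit of > 100000 nM in this assay, at which 2 of the 4 values shown sit.

On these data alone, it remains open whether a different group on this carbon, such as an amine or a carboxylic acid, would lower the number further than hydrogen does. As far as these compounds go, it is also open what the bromo group itself contributes, for instance whether a hydrogen or a methoxy group in its place would shift the number.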